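Chain Lengthening on an Amide-Linked Threonine Scaffold

The compounds below may be only part of what the source reports. "The series", "measured", "known", "first", "only" and "open" are said of these compounds alone.

Three amides built on a common threonine-derived core have been tested in a functional assay on HepG2 cells (Homo sapiens) for cytotoxicity, read by MTT assay, with a stated time of 48 h; a higher number here means a weaker inhibitor, a lower number a stronger inhibitor. Compound 1 `CCCCCCCCNC(=O)[C@@H](NC(=O)c1cccs1)[C@@H](C)O` gives 149000 nM in this assay. Among the compounds with values here, compound 3 `CCCCCCCCNC(=O)[C@@H](NC(=O)/C=C/c1ccccc1)[C@@H](C)O` gives 55600 nM, and the step of a 2.7-fold lower number from compound 1 to compound 3 (0.43 log units; beyond the scatter) is the only comparison among the measured compounds that changes one place at a time. Compound 2 `CCCCCCCCNC(=O)[C@@H](NC(=O)c1nccc2ccccc12)[C@@H](C)O` gives 88200 nM and stands second highest of the three numbers, within the scatter of both compound 3 and compound 1.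

Compound 4 `CCCCCCCCCCCCNC(=O)[C@@H](NC(=O)c1nccc2ccccc12)[C@@H](C)O` differs from compound 2 by butyl in place of hydrogen on a saturated chain carbon, eight bonds along the chain from an amide-type nitrogen. Within the data shown here, none of the measured steps concerns this part of the molecule: the single counted step, from compound 1 to compound 3, alters the group on the carbonyl carbon and leaves the octyl chain untouched. Among the measured compounds shown here, there is therefore no measured precedent for extending the chain, and the expectation for compound 4 rests only on the observation that the three measured values lie close together and that the change here is a modest one. In this assay compound 4 is expected to give about 50000 nM, with a plausible range from 15000 nM to 150000 nM, corresponding to an expected step of a 1.8-fold lower number from compound 2 to compound 4 (0.25 log units; within the scatter).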

Compound 4, half-maximal inhibitory concentration: 65700 nM
Compound 4: the middle estimate sits 1.3-fold (0.12 log units) below what was measured, within the range that was stated.
By their numbers in this assay, from the lowest: compounds 3, 4, 2 and 1 (each within the scatter of the next, the first and the last beyond it).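

Within the data shown here, with this pair, the chain itself changes for the first time, while the group on the carbonyl carbon stays as it is in compound 2. In this assay, butyl in place of hydrogen on a saturated chain carbon, eight bonds along the chain from an amide-type nitrogen, gives a 1.3-fold lower number from compound 2 to compound 4 (0.13 log units; within the scatter), so adding these 4 carbon atoms to the octyl chain leaves no change that can be told from the scatter, unlike the earlier step on the carbonyl side, which lay beyond it. No measurement of any property of these compounds is available to bear on this result.

Among these compounds, the chain change has been read on only one carbonyl group, so it remains open whether the same lengthening would leave compound 1 or compound 3 equally unmoved. Also open, from the compounds shown here alone, is how this position would respond to a still longer chain, or to a chain ending in an amine or a carboxylic acid.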